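The source may report more compounds than this note shows. Statements on the series, on what has been measured and on what is new or still open speak of the compounds shown alone.

Of the compounds shown here, three that share one core have been tested in a functional assay on MV4-11 cells (Homo sapiens) for inhibition, read by resazurin assay, with a stated time of 72 h; on this read-out higher numbers stand for weaker inhibition of growth and lower numbers for stronger inhibition of growth. Compound 1 `O=C1NCCC12CCN(c1c(Cl)cncc1-c1ccco1)CC2` gives 940 nM. Compound 2 `O=C1NCCC12CCN(c1c(Cl)cncc1-c1cc[nH]c1)CC2` gives 1050 nM, the highest of the three numbers, although its gap to compound 1 is within the scatter. Compound 3 `O=C1NCCC12CCN(c1c(Cl)cncc1-c1ccc(Cl)s1)CC2` gives 560 nM. The step of a 1.9-fold lower number from compound 2 to compound 3 (0.27 log units; within the scatter), the step of a 1.7-fold lower number from compound 1 to compound 3 (0.22 log units; within the scatter) and the step of a 1.1-fold higher number from compound 1 to compound 2 (0.05 log units; within the scatter) all stay within the scatter; so far, exchanging one five-membered aromatic ring for another has moved the numbers little.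

Compound 4 `O=Cc1cc(-c2cncc(Cl)c2N2CCC3(CCNC3=O)CC2)cs1` has not yet been measured. It differs from compound 2 in one place: 5-formylthiophen-3-yl in place of 1H-pyrrol-3-yl on an aromatic carbon. The step from compound 2 to compound 3 bears most directly on this change, since both put a thiophene ring in place of 1H-pyrrol-3-yl, and that step was small. A comparably small step in this assay is therefore expected, possibly toward a slightly lower number but not beyond the scatter. Compound 4 is estimated at 650 nM, between 300 nM and 1400 nM. This estimate means an expected step of a 1.6-fold lower number from compound 2 to compound 4 (0.21 log units; within the scatter).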

Compound 4, concentration for 50% growth inhibition: 730 nM
Compound 4: the middle estimate sits 1.1-fold (0.05 log units) below what was measured; the measured number falls inside the stated range.
By their numbers in this assay, from the lowest: compounds 3, 4, 1 and 2 (each within the scatter of the next).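

In this assay the exchange of 1H-pyrrol-3-yl for 5-formylthiophen-3-yl gives a 1.4-fold lower number from compound 2 to compound 4 (0.16 log units; within the scatter) even though the entering group carries a carbonyl, has more heavy atoms and has no hydrogen-bond donor. The same group, set against the other two rings, gives a 1.3-fold higher number from compound 3 to compound 4 (0.12 log units; within the scatter) and a 1.3-fold lower number from compound 1 to compound 4 (0.11 log units; within the scatter) so that this place on the shared core now holds a hydrogen-bond donor, a chloro substituent or a formyl substituent on its five-membered ring with no step beyond the scatter. Nothing here explains why the read-out stays so close across these changes.

All four compounds carry a five-membered aromatic ring at this place, so a six-membered ring such as phenyl remains untested in what is shown. Also open, going by these compounds, is whether a carboxylic acid or an aminomethyl group in place of the formyl would keep the number this close.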